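Dibromination in a thiosulfate sulfurtransferase amide series

The source may report more compounds than this note shows. Statements on the series, on what has been measured and on what is new or still open speak of the compounds shown alone.

Compound 1 `O=C(Nc1cccc(Cl)c1)c1cc(Br)cc(Br)c1`, compound 2 `O=C(Nc1cccc(Cl)c1)c1cccc(Br)c1` and compound 3 `O=C(Nc1ccc(Sc2nc3ccccc3s2)cc1)c1cccc(Br)c1O` have been tested in an assay on isolated protein for inhibition of thiosulfate sulfurtransferase (Homo sapiens), with a stated time of 60 min, in the absence of a further agent; on this read-out higher numbers stand for weaker inhibition and lower numbers for stronger inhibition. Compound 1 gives only a limit of the assay, > 100000 nM. Compound 2 likewise gives only a limit, > 100000 nM. Compound 3 also gives only a limit, > 100000 nM. The change from compound 2 to compound 1 is bromo in place of hydrogen on an aromatic carbon, and the size of that step, a step that the two limits leave unreadable from compound 2 to compound 1, cannot be read because the limit of > 100000 nM in this assay, at which 3 of the 3 values shown sit, holds both ends of it. How the core of compound 3 differs from the core of compound 2 is not broken down here.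

Compound 4 `O=C(Nc1ccc(Sc2nc3ccccc3s2)cc1)c1cc(Br)cc(Br)c1O` has not yet been measured in this assay. It is made from compound 3 by bromo in place of hydrogen on an aromatic carbon. For the measured compounds named here, this is the same kind of change as the one from compound 2 to compound 1, though the surroundings are not identical: in compound 4 the entering bromo also sits para to a hydroxy group, which has no counterpart in compound 1.

Going by the values given here, every value shown so far is a limit, so no measured step gives a direction for this change. On that basis the step from compound 3 to compound 4 is expected to be about a step that the limit leaves unreadable from compound 3 to compound 4, and compound 4 is estimated at 150000 nM, with a likely range from 30000 nM to 1000000 nM, the most probable outcome being that the assay again reports only a limit.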

Compound 4, half-maximal inhibitory concentration: > 100000 nM
Compound 4 gave a limit, no number; the forecaster's own chance of this, stated with the estimate: 75%; the middle value is on the limit's open side.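

In this assay compound 4 gives > 100000 nM, which is a limit and not a number. No step from compound 3 to compound 4 can be read, because both compounds sit at the same limit: the limit of > 100000 nM in this assay, at which 4 of the 4 values shown sit.

The compounds shown leave open whether bromo in place of hydrogen on an aromatic carbon changes inhibition in either pair, compound 2 with compound 1 or compound 3 with compound 4.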